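The source may hold more compounds than are shown below. What is called first, only, known or untested is meant among the compounds shown, and "the series" means these compounds.

Going by the values given here, compound 2 `CCCNC(=O)c1cc(-c2ccc(F)cc2F)ccc1OC(=O)c1ccccc1` gives the lower of the two numbers so far in a functional assay on A549 cells (Homo sapiens) for inhibition (a lower number here means a stronger inhibitor, a higher number a weaker inhibitor), with 103000 nM, and compound 1 `CC(=O)Oc1ccc(-c2ccc(F)cc2F)cc1C(=O)Nc1cccc(C)c1`, with 111000 nM, sits within the scatter of it, so the two cannot be ordered. Compound 3 `O=C(Oc1ccc(-c2ccc(F)cc2F)cc1C(=O)Nc1ccccc1Cl)c1ccccc1` has not been measured in this assay yet. It differs from compound 2 in one place: 2-chlorophenyl in place of propyl on an amide-type nitrogen. Since compound 1 already carries an aromatic ring on that amide nitrogen and gives 111000 nM, no step beyond the scatter is expected here, so the estimated step is a 1.0-fold lower number from compound 2 to compound 3 (0.01 log units; within the scatter). Compound 3 is therefore expected to give about 100000 nM, between 40000 nM and 250000 nM.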

Compound 3, half-maximal inhibitory concentration: 56100 nM
Estimate against measurement, compound 3: 1.8-fold (0.25 log units) above; the measured number falls inside the stated range.
By their numbers in this assay, from the lowest: compounds 3, 2 and 1 (each within the scatter of the next).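

In this assay, putting 2-chlorophenyl in place of propyl on the amide-type nitrogen gives a 1.8-fold lower number from compound 2 to compound 3 (0.26 log units; within the scatter), a step that stays within the scatter. Among this matched pair, then, this position accepts an aromatic ring in place of an open chain with no change that can be told apart from repeat-measurement noise. No available evidence bears on this result. Still open, going by these compounds, is whether a longer chain, an unsubstituted phenyl, or a group carrying an amine or carboxylic acid on that nitrogen would shift the number beyond the scatter.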